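A few compounds are considered here, and "the series" means these few. Any claim that something is new, unique, unknown or untested is made for them only; others in the source may bear on it.

Three compounds sharing one core were tested in a functional assay on C6 cells (Rattus norvegicus) for cytotoxicity, read by MTT assay, with a stated time of 24 h, tested at 50 ug/mL; on this read-out higher numbers stand for a weaker effect at the one concentration tested and lower numbers for a stronger effect. Compound 1 `O=C(CSc1nnnn1-c1ccccc1)N/N=c1/scc(-c2ccc(Br)cc2)n1-c1ccccc1` gives 32%. Compound 2 `O=C(CSc1nnnn1-c1ccccc1)N/N=c1/scc(-c2ccc(F)cc2)n1-c1ccccc1` gives 43.7%, and compound 3 `O=C(CSc1nnnn1-c1ccccc1)N/N=c1/scc(-c2ccc(Cl)cc2)n1-c1ccccc1` gives 60%. Compound 1 thus stands lowest of the three numbers: the step of a number 11.7 percentage points higher from compound 1 to compound 2 (beyond the scatter) and the step of a number 28 percentage points higher from compound 1 to compound 3 (beyond the scatter) both lie beyond the scatter, as does the step of a number 16.3 percentage points higher from compound 2 to compound 3 (beyond the scatter). Each of these three measured steps exchanges one halogen for another on an aromatic carbon, and nothing else.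

Compound 4 `O=C(CSc1ncccn1)N/N=c1/scc(-c2ccc(Br)cc2)n1-c1ccccc1` departs from compound 1 at a different place: pyrimidin-2-yl in place of 1-phenyl-1H-tetrazol-5-yl on a sulfur. Among the measured compounds shown here, no measured pair touches this part of the shared core, so none of the three steps bears on the change, and the numbers give no direction for it. With no guide beyond the value of compound 1, compound 4 is expected to give 40%, within a wide range from 20% to 75%. The expected step in this assay is a number 8 percentage points higher from compound 1 to compound 4 (within the scatter), held with low confidence.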

Compound 4, a percentage reported as activity, at one concentration (the size of the read-out at that concentration, not a potency): 69%
Compound 4: the middle estimate sits 29 percentage points below what was measured; the range from low to high includes it.
By their numbers in this assay, from the lowest: compound 1; then compound 2; then compounds 3 and 4 (each within the scatter of the next).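

Among the compounds shown here, the group on the sulfur turns out to matter in this assay: with the bromo substituent kept, the exchange gives a number 37 percentage points higher from compound 1 to compound 4 (beyond the scatter), a step graded large, whereas each halogen exchange among the earlier compounds was graded modest. On this read-out the higher number stands for a weaker effect at the one concentration tested, so the 1-phenyl-1H-tetrazol-5-yl group goes with the stronger effect in this one pair. Nothing available explains why the two groups differ.

The compounds shown leave open whether the same exchange would carry the same size and direction with fluoro or chloro in place of bromo, and the single pair cannot separate the contribution of the phenyl ring from that of the tetrazole. Going by these compounds, it also remains open what a pyridin-2-yl group or a simple methyl on that sulfur would give.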